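Replacing 3,4-dichlorophenyl with 3-methylphenyl on compound 2

The source may report more compounds than this note shows. Statements on the series, on what has been measured and on what is new or still open speak of the compounds shown alone.

Measured in a physicochemical assay for solubility, at pH 7.4; a higher number here means a more soluble compound, a lower number a less soluble compound:
Compound 1 `CC(C)(C)c1cc(Nc2ccc(Cl)cc2Cl)ncc1C(=O)NCC1CCOCC1`: 23 ug/mL
Compound 2 `O=C(NCC1CCOCC1)c1cnc(Nc2ccc(Cl)c(Cl)c2)cc1C1CC1`: 6 ug/mL
Compound 3 `N#Cc1cccc(Nc2cc(C3CC3)c(C(=O)NCC3CCOCC3)cn2)c1`: 4 ug/mL

In this assay compound 2 gives 6 ug/mL, which lies within the scatter of compound 3 at 4 ug/mL. Compound 1 stands apart with 23 ug/mL, a number beyond the scatter from that of compound 2.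

Compound 4 `Cc1cccc(Nc2cc(C3CC3)c(C(=O)NCC3CCOCC3)cn2)c1` has not yet been measured. It carries 3-methylphenyl in place of 3,4-dichlorophenyl on a nitrogen on an aromatic ring.

Within the data shown here, one measured step bears on this change, since it leaves the same group at the same place. Putting 3-cyanophenyl in place of 3,4-dichlorophenyl gave a 1.5-fold lower number from compound 2 to compound 3 (0.18 log units; within the scatter). Among the measured compounds shown here, compound 1 differs from compound 2 in more than one place, so it offers no comparable step. A single step within the scatter is thin evidence, but on the strength of it no change beyond the scatter is expected in this assay, and no direction can be firmly expected either.

The expected step is a 1.2-fold higher number from compound 2 to compound 4 (0.07 log units; within the scatter). For compound 4 the estimated value is 7 ug/mL, with an expected range from 3 ug/mL to 16 ug/mL.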

Compound 4, solubility: 26 ug/mL
Compound 4: middle estimate off by 3.7-fold (0.57 log units), on the low side, outside the stated range (above it).
By their numbers in this assay, from the lowest: compounds 3 and 2 (each within the scatter of the next); then compounds 1 and 4 (each within the scatter of the next).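

In this assay the group on this nitrogen proves able to shift the number: the change gives a 4.3-fold higher number from compound 2 to compound 4 (0.64 log units; beyond the scatter) whereas the only earlier step at this place was a 1.5-fold lower number from compound 2 to compound 3 (0.18 log units; within the scatter) and so had shown no clear change. The second new step points the same way, since methyl in place of cyano on an aromatic carbon gives a 6.5-fold higher number from compound 3 to compound 4 (0.81 log units; beyond the scatter) and thus sets 3-methylphenyl apart from both groups measured before it at this nitrogen. The step from 3,4-dichlorophenyl to 3-methylphenyl leaves the hydrogen-bond donor and acceptor counts and the net charge unchanged, so these counts do not separate the two groups, and the higher number cannot be traced to them.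

The compounds shown leave open whether the methyl group itself matters or whether any group other than chlorine or cyano would do as well, as a plain phenyl or a methoxyphenyl on this nitrogen could tell, and whether the same step would hold on the core of compound 1. Nothing measured here accounts for the size of these steps.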